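Closing the amine of compound 1 into a pyrrolidine ring

A few compounds are considered here, and "the series" means these few. Any claim that something is new, unique, unknown or untested is made for them only; others in the source may bear on it.

Compound 1 `O=C1C=C(NC2CCCC2)C(=O)c2c1nc1n2[C@H]2OC[C@@H](O)[C@H]2OC1`: in a functional assay on ECa-109 cells for inhibition, with ECa-109 cell line (Homo sapiens) as the target, read by sulforhodamine B assay (on this read-out lower numbers stand for stronger inhibition and higher numbers for weaker inhibition), compound 1 reaches only a limit of the assay, > 16000 nM.
Compound 2 `CCCc1ccc(NC2=CC(=O)c3nc4n(c3C2=O)[C@H]2OC[C@@H](O)[C@H]2OC4)cc1`: in this assay compound 2 likewise ends at a limit, > 4000 nM.
Compound 3 `CCOc1ccc(NC2=CC(=O)c3nc4n(c3C2=O)[C@H]2OC[C@@H](O)[C@H]2OC4)cc1`: in this assay compound 3 gives 3210 nM.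

For compound 1 only a limit is known, and of the three values shown two are limits, so compound 1 cannot be ranked by a number at all (the limit of > 16000 nM in this assay, at which 1 of the 3 values shown sits, (the limit of > 4000 nM in this assay, at which 1 of the 3 values shown sits)). Compound 4 `O=C1C=C(N2CCCC2)C(=O)c2c1nc1n2[C@H]2OC[C@@H](O)[C@H]2OC1` differs from compound 1 in one place: pyrrolidin-1-yl in place of cyclopentylamino on a double-bonded ring carbon. The amine hydrogen present in compound 1 is absent in compound 4, whose nitrogen belongs to the ring itself.

The measured steps all start from the same cyclopentylamino group and keep its hydrogen: a step that the two limits leave unreadable from compound 1 to compound 2, and an at least 4.9-fold lower number from compound 1 to compound 3 (0.69 log units; beyond the scatter). The step of an at least 1.2-fold lower number from compound 2 to compound 3 (0.09 log units; that floor lies within the scatter) touches only a substituent on the aromatic ring. For the measured compounds named here, none of these removes the amine hydrogen or turns the amine into part of a ring, so no measured step speaks directly to compound 4. The only anchor is the limit of compound 1, and the expected step that the limit leaves unreadable from compound 1 to compound 4 is therefore none beyond the scatter. Compound 4 is estimated at 20000 nM, within a range of 6000 nM to 60000 nM, most probably reported again only as a limit.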

Compound 4, half-maximal inhibitory concentration: > 16000 nM
Compound 4: only a limit was reported (the forecaster's own chance of this, stated with the estimate: 75%); the middle value does not contradict the limit.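

No step can be read from compound 1 to compound 4, because both compounds stop at the same limit of the assay rather than at a number: the limit of > 16000 nM in this assay, at which 2 of the 4 values shown sit.

As far as these compounds go, whether pyrrolidin-1-yl in place of cyclopentylamino, which removes the amine hydrogen, changes inhibition at all remains open, since neither compound gives a measured value to compare.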